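A few compounds are considered here, and "the series" means these few. Any claim that something is new, unique, unknown or untested is made for them only; others in the source may bear on it.

Of the compounds shown here, three measured so far share one core. In an assay on a cell-free system (plasma) for inhibition of Dipeptidyl peptidase 4 (Rattus norvegicus), read by fluorescence, with a stated time of 60 min (on this read-out higher numbers stand for weaker inhibition and lower numbers for stronger inhibition), compound 1 `O=C([C@@H]1C[C@H](N2CCN(c3nc(-c4ccccc4)cs3)CC2)CN1)N1CCSC1` gives 5.4 nM, compound 2 `O=C([C@@H]1C[C@H](N2CCN(c3nnnn3C3CCCCC3)CC2)CN1)N1CCSC1` gives 3.1 nM and compound 3 `Cc1cc(N2CCN([C@@H]3CN[C@H](C(=O)N4CCSC4)C3)CC2)n(-c2ccc(F)cc2)n1` gives 2.3 nM. Compound 3 holds the lowest of the three numbers; its value and that of compound 2 lie within the scatter of each other, while the gap to compound 1 lies beyond it. Compound 4 `Cc1cc(N2CCN([C@@H]3CN[C@H](C(=O)N4CCSC4)C3)CC2)n(-c2cccc(F)c2)n1` differs from compound 3 in one place: 3-fluorophenyl in place of 4-fluorophenyl on an aromatic nitrogen. Going by the values given here, no measured pair shows this change, so the step has no precedent in this assay; the expectation is a step no larger than the scatter, in no set direction. For compound 4 the expected value in this assay is 3 nM, with a range from 1.2 nM to 8 nM. That estimate means a 1.3-fold higher number from compound 3 to compound 4 (0.12 log units; within the scatter).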

Compound 4, half-maximal inhibitory concentration: 0.49 nM
For compound 4 the middle estimate is 6.1-fold (0.79 log units) above the measured one, outside the stated range (below it).
By their numbers in this assay, from the lowest: compound 4; then compounds 3, 2 and 1 (each within the scatter of the next, the first and the last beyond it).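

In this assay, moving the fluorine on the phenyl group carried by the aromatic nitrogen gives a 4.7-fold lower number from compound 3 to compound 4 (0.67 log units; beyond the scatter), a step beyond the scatter. The earlier compounds shown here showed no change at this position; this pair shows that it responds to a swap of 4-fluorophenyl for 3-fluorophenyl, even though the atoms and the counted features stay the same. No available evidence bears on the reason for this step. The compounds shown leave open whether fluorine itself is needed, since neither a plain phenyl nor a 3-chlorophenyl appears at this position.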